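Replacing cyclopropylmethoxy with ethylsulfanyl in compound 3

The source may report more compounds than this note shows. Statements on the series, on what has been measured and on what is new or still open speak of the compounds shown alone.

Values in a functional assay on the whole organism (strain Sprague-Dawley) for inhibition, with Rattus norvegicus as the target, with a stated time of 10 min; a higher number here means that more compound is needed for the effect, a lower number that less compound is needed:
compound 1 `O=C(O)c1cnc(-c2ccccc2Cl)[nH]c1=O` gives 5 mg/kg
compound 2 `COc1ccccc1-c1ncc(C(=O)O)c(=O)[nH]1` gives 10 mg/kg
compound 3 `O=C(O)c1cnc(-c2ccccc2OCC2CC2)[nH]c1=O` gives 0.1 mg/kg
compound 4 `CCSc1ccccc1-c1ncc(C(=O)O)c(=O)[nH]1` has not yet been measured

Compound 3 has the lowest number of the three in this assay, and its steps to both other compounds lie beyond the scatter. In compound 4, ethylsulfanyl stands in place of cyclopropylmethoxy on an aromatic carbon of a six-membered aromatic ring of carbon only, ortho to a large group (ethylsulfanyl in place of cyclopropylmethoxy on an aromatic carbon).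

Two measured steps at this same place bear on the change: a 50-fold lower number from compound 1 to compound 3 (1.70 log units; beyond the scatter) and a 100-fold lower number from compound 2 to compound 3 (2.00 log units; beyond the scatter). Both are large. The remaining step, a 2.0-fold higher number from compound 1 to compound 2 (0.30 log units; within the scatter), shows no difference beyond the scatter. For the measured compounds named here, no measured compound carries ethylsulfanyl, so the size of this step can only be judged indirectly. Compound 4 has no cyclopropyl, and adding that group gave a 100-fold lower number from compound 2 to compound 3 (2.00 log units; beyond the scatter). A clear rise in the number is therefore expected, though probably not all the way back to the values of the two compounds without it.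

The expected change is a 10-fold higher number from compound 3 to compound 4 (1.00 log units; beyond the scatter). For compound 4 the estimate is 1 mg/kg, with an expected range from 0.2 mg/kg to 5 mg/kg.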

Compound 4, dose for 50% inhibition: 25 mg/kg
Compound 4: middle estimate off by 25-fold (1.40 log units), on the low side; the whole stated range lies below it.
By their numbers in this assay, from the lowest: compound 3; then compounds 1 and 2 (each within the scatter of the next); then compound 4.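

In this assay, the low number of compound 3 does not carry over to ethylsulfanyl at this place on the aromatic ring, a 250-fold higher number from compound 3 to compound 4 (2.40 log units; beyond the scatter), so among the four groups shown only cyclopropylmethoxy gives such a low number. Ethylsulfanyl does not even come level with the two smaller comparison groups: the change is a 5.0-fold higher number from compound 1 to compound 4 (0.70 log units; beyond the scatter) and a 2.5-fold higher number from compound 2 to compound 4 (0.40 log units; beyond the scatter), both modest but beyond the scatter, which leaves compound 4 with the highest number of the four. For the compounds shown here, nothing available explains why this change raises the number so far.

The step from compound 3 to compound 4 swaps oxygen for sulfur and also removes the three-membered ring, so these compounds cannot separate the two changes. Ethoxy would isolate the loss of the ring with oxygen kept, cyclopropylmethylsulfanyl would isolate the swap to sulfur with the ring kept, and it remains open whether other ether groups, such as propoxy or cyclobutylmethoxy, would match the low number of compound 3.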